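A Methoxypyridine in Place of a Trifluoromethoxyphenyl Group

The source may report more compounds than this note shows. Statements on the series, on what has been measured and on what is new or still open speak of the compounds shown alone.

Among the compounds with values here, compound 1 `CCS(=O)(=O)Nc1cc(-c2ccc3ncnc(Nc4ccc(OC(F)(F)F)cc4)c3c2)cnc1OC` was tested in a functional assay on SK-HEP1 cells (Homo sapiens) for cytotoxicity, read by sulforhodamine B assay, with a stated time of 72 h (a higher number here means a weaker inhibitor, a lower number a stronger inhibitor), where compound 1 gave 6140 nM, the highest of the two numbers measured so far. Within the data shown here, its nearest neighbour, compound 2 `CCS(=O)(=O)Nc1cc(-c2ccc3ncnc(Nc4ccc(OC)c(OC)c4)c3c2)cnc1OC`, gives 2840 nM in this assay, and the one recorded step between them, a 2.2-fold lower number from compound 1 to compound 2 (0.33 log units; beyond the scatter), was modest in size. The unmeasured compound 3 `CCS(=O)(=O)Nc1cc(-c2ccc3ncnc(Nc4ccc(OC)nc4)c3c2)cnc1OC` differs from compound 1 in a single place: 6-methoxypyridin-3-yl in place of 4-(trifluoromethoxy)phenyl on a nitrogen on an aromatic ring. Among the measured compounds shown here, no measured step makes exactly this change; the only related step is the one from compound 1 to compound 2, which also replaces the same group on the same nitrogen and moved the number only a little. A small lowering, or no movement beyond the scatter, is therefore expected, and compound 3 is estimated at 4000 nM with a range from 1500 nM to 12000 nM. That estimate corresponds to an expected step of a 1.5-fold lower number from compound 1 to compound 3 (0.19 log units; within the scatter).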

Compound 3, half-maximal inhibitory concentration: 3440 nM
For compound 3 the middle estimate is 1.2-fold (0.07 log units) above the measured one; the range from low to high includes it.
By their numbers in this assay, from the lowest: compounds 2, 3 and 1 (each within the scatter of the next, the first and the last beyond it).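

Replacing the 4-(trifluoromethoxy)phenyl group on this nitrogen with 6-methoxypyridin-3-yl gives a 1.8-fold lower number from compound 1 to compound 3 (0.25 log units; within the scatter) in this assay, so a ring with a hetero atom can stand at this position without a change that can be told from assay noise. Set against the other oxygen-bearing ring, the same position gives a 1.2-fold higher number from compound 2 to compound 3 (0.08 log units; within the scatter), so 6-methoxypyridin-3-yl and 3,4-dimethoxyphenyl cannot be separated here, even though the step between compound 1 and compound 2 lies beyond the scatter. Nothing available explains why these three groups read so closely.

Going by these compounds, all three groups on this nitrogen carry oxygen-linked substituents, so the effect of an amine or a carboxylic acid in place of the methoxy group of compound 3 remains open. On these data alone, whether any group at this position can move the number much further also remains unknown.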